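The source may report more compounds than this note shows. Statements on the series, on what has been measured and on what is new or still open speak of the compounds shown alone.

Measured compounds:
compound 1, `CCn1cc(-c2nc3ccccc3[nH]2)c(=O)c2cc(F)c(N3CCNCC3)cc21`: > 10000 nM in a functional assay on THP-1 cells (Homo sapiens) for cytotoxicity, read by sulforhodamine B assay, with a stated time of 48 h; on this read-out lower numbers stand for stronger inhibition and higher numbers for weaker inhibition
compound 2, `CCn1cc(-c2nc3ccc([N+](=O)[O-])cc3o2)c(=O)c2cc(F)c(N3CCNCC3)nc21`: > 10000 nM in this assay

Two compounds have been run in this assay, and neither gives a number. For compound 1 the assay reports only a limit, > 10000 nM. For compound 2 it likewise reports only a limit, > 10000 nM. Both measured values therefore sit at the limit of > 10000 nM in this assay, at which 2 of the 2 values shown sit, so compound 1 cannot be placed in order against compound 2; the two values show only that neither reaches a measurable potency in this assay. Going by the values given here, no step between measured compounds is available, and nothing within the measured set tells how a change on the shared core moves the read-out.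

The next compound, compound 3, has the structure `CCn1cc(-c2nc3ccc(N)cc3[nH]2)c(=O)c2cc(F)c(N3CCNCC3)cc21`. It differs from compound 1 by amino in place of hydrogen on an aromatic carbon. With both known values at the limit, the step in this assay from compound 1 to compound 3 is expected to be none beyond the scatter, in no particular direction. Compound 3 is accordingly estimated at 15000 nM, with a range from 3000 nM to 60000 nM. The expected step is a step that the limit leaves unreadable from compound 1 to compound 3, most likely reported again as a limit rather than a number.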

Compound 3, half-maximal inhibitory concentration: 10000 nM
Estimate against measurement, compound 3: 1.5-fold (0.18 log units) above; the range from low to high includes it.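

In this assay, going by these compounds alone, amino in place of hydrogen on this aromatic carbon gives the first value that is a number rather than a limit, with compound 3 at 10000 nM. The value of compound 1, > 10000 nM, is a limit. The change therefore reads as a number no higher from compound 1 to compound 3 (the limit leaves the size open), and it does not show that amino separates compound 3 from the compounds held at the limit: the limit of > 10000 nM in this assay, at which 2 of the 3 values shown sit.

The compounds shown leave open whether a hydroxyl group, a carboxylic acid or an acetamide on the same aromatic carbon would give a lower number in this assay than amino does. They also leave open whether amino at this place would give a number on the core of compound 2, which differs from compound 1 in more than one place.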